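The compounds below may be only part of what the source reports. "The series", "measured", "known", "first", "only" and "open" are said of these compounds alone.

Of the compounds shown here, three sharing one core have been measured in a functional assay on HT-1080 cells (Homo sapiens) for antiproliferative activity, read by MTT assay, with a stated time of 72 h; a lower number here means a stronger inhibitor, a higher number a weaker inhibitor. Compound 1 `CCOC(=O)c1cc(-c2cc(OC)c(OC)c(OC)c2)c(-c2cccc(Br)c2)s1` carries a 3-bromophenyl group; in this assay compound 1 gives only a limit, > 100000 nM. Compound 2 `CCOC(=O)c1cc(-c2cc(OC)c(OC)c(OC)c2)c(-c2ccc(OC)c([N+](=O)[O-])c2)s1` bears a 4-methoxy-3-nitrophenyl group instead, and in this assay compound 2 gives 12700 nM. Compound 3 `CCOC(=O)c1cc(-c2cc(OC)c(OC)c(OC)c2)c(-c2ccc3ccccc3c2)s1` carries naphthalen-2-yl, and in this assay compound 3 gives 1150 nM. Among the two numbers, compound 2 stands highest; the nearest is compound 3, reached by an 11-fold lower number from compound 2 to compound 3 (1.04 log units; beyond the scatter). The other steps, an at least 7.8-fold lower number from compound 1 to compound 2 (0.89 log units; beyond the scatter) and an at least 86-fold lower number from compound 1 to compound 3 (1.93 log units; beyond the scatter), both start from a limit (the limit of > 100000 nM in this assay, at which 1 of the 3 values shown sits).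

The step to compound 4 `COc1ccc(-c2sccc2-c2cc(OC)c(OC)c(OC)c2)cc1[N+](=O)[O-]` is of a different kind: hydrogen in place of ethoxycarbonyl on an aromatic carbon. For the measured compounds named here, every measured step exchanges the aryl group attached to the core, while the ethoxycarbonyl group stays in place throughout; no measured step therefore bears on its removal, and the data give no direction for this change. Compound 4 is expected to stay in the region of compound 2, with a wide margin, so the estimated step is a 1.6-fold higher number from compound 2 to compound 4 (0.20 log units; within the scatter). The estimate for compound 4 is 20000 nM, between 4000 nM and 100000 nM.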

Compound 4, half-maximal inhibitory concentration: 2100 nM
Estimate against measurement, compound 4: 9.5-fold (0.98 log units) above; the measured number lies below the stated range.
By their numbers in this assay, from the lowest: compounds 3 and 4 (each within the scatter of the next); then compound 2. At a limit, above all of these: compound 1.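

In this assay, the ethoxycarbonyl group turns out not to be required at this position: with the 4-methoxy-3-nitrophenyl group held fixed, hydrogen in its place gives a 6.0-fold lower number from compound 2 to compound 4 (0.78 log units; beyond the scatter). For the compounds shown here, the earlier steps all exchanged the aryl group, so this is the first measured change at the aromatic carbon next to the ring sulfur; it shows that this site also moves the number beyond the scatter, and that losing these 5 heavy atoms goes with a stronger inhibitor rather than a weaker one. Nothing in the data at hand accounts for the direction or size of this step.

This single pair leaves open whether hydrogen in place of ethoxycarbonyl would give a step of like direction and size with the 3-bromophenyl or naphthalen-2-yl group in place of the 4-methoxy-3-nitrophenyl group. It also leaves open how a carboxylic acid, a primary amide or a methyl group on the same carbon would compare with hydrogen and ethoxycarbonyl.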